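The source may hold more compounds than are shown below. What is called first, only, known or untested is meant among the compounds shown, and "the series" means these compounds.

Measured so far in an ADME assay (liver) for metabolic stability, with Liver microsome (Rattus norvegicus) as the target, read by LC-MS, using microsomes and NADPH, with stated times of 5 min and 60 min, tested at 4 uM; on this read-out lower numbers stand for a less stable compound and higher numbers for a more stable compound:

compound 1 `Cc1c(OCCCCOc2ccc(C(=O)O)cc2)ccc(C(=O)CC(C)C)c1O`: 66%
compound 2 `Cc1cc(OCCCCOc2ccc(C(=O)CC3CCCC3)c(O)c2C)ccc1C(=O)O`: 55%
compound 3 `Cc1c(OCCCCOc2ccc(F)c(C(=O)O)c2)ccc(C(=O)CC(C)(C)C)c1O`: 58%

Compound 2 gives the lowest of the three numbers. Compound 3 stands within the scatter of compound 2; compound 1 stands beyond it, higher.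

Compound 4 `Cc1cc(C(=O)O)ccc1OCCCCOc1ccc(C(=O)CC2CCCC2)c(O)c1C` is not yet measured. It differs from compound 2 in one place, with the same atoms joined differently: 4-carboxy-2-methylphenyl in place of 4-carboxy-3-methylphenyl on an oxygen on a saturated carbon.

For the measured compounds named here, no step between two measured compounds differing only in such a place is available, so its direction is open. The expected step of a number 2 percentage points higher from compound 2 to compound 4 (within the scatter) is none beyond the scatter in this assay.

Compound 4 is estimated at 57%, between 44% and 70%, because compound 2 gives 55%.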

Compound 4, percent of the compound remaining: 59%
Compound 4: middle estimate off by 2 percentage points, on the low side; low and high end bracket the measured number.
By their numbers in this assay, from the lowest: compounds 2, 3, 4 and 1 (each within the scatter of the next, the first and the last beyond it).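

Within the series, 4-carboxy-2-methylphenyl in place of 4-carboxy-3-methylphenyl on an oxygen on a saturated carbon gives in this assay a step of a number 4 percentage points higher from compound 2 to compound 4 (within the scatter) and so leaves the read-out unchanged within the scatter. For the compounds shown here, this is the first single-place step available, and it shows that this rearrangement of the same atoms on this end of the molecule does not separate the two compounds. Nothing measured here bears on the reason for this result.

Still open, from the compounds shown here alone, is whether a methoxy group or a chlorine in place of the methyl would behave the same way. Going by these compounds, an amide in place of the carboxylic acid is equally open.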